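This account rests on a few compounds, and the source may have more. Where it says the series, first, only, none or still open, it means among the compounds named here.

In a functional assay on Huh-7 cells (Homo sapiens) for inhibition, read by MTT assay, with a stated time of 48 h (a lower number here means a stronger inhibitor, a higher number a weaker inhibitor), compound 1 (`COc1ccc(CNC(=O)/C=C/c2coc3cc(O)ccc3c2=O)cc1`) gives 8430 nM. Compound 2 (`COc1ccc(CNC(=O)/C=C/c2coc3cc(OC)ccc3c2=O)cc1`) gives 7570 nM, and the step of a 1.1-fold lower number from compound 1 to compound 2 (0.05 log units; within the scatter) leaves the two level. Compound 3 (`COc1ccc2c(=O)c(/C=C/C(=O)Nc3ccc(F)cc3)coc2c1`) has a higher number, at 33900 nM, so compound 1 shares the lower end of this small set with compound 2. The unmeasured compound 4 (`O=C(/C=C/c1coc2cc(O)ccc2c1=O)NCc1ccc(F)cc1F`) keeps the core of compound 1 but carries 2,4-difluorophenyl in place of 4-methoxyphenyl on the saturated chain carbon bound to the amide-type nitrogen: 2,4-difluorophenyl in place of 4-methoxyphenyl on a saturated chain carbon bound to an amide-type nitrogen. The change at the oxygen on the aromatic ring does not touch this part of the molecule, so it offers little guidance. The closer precedent is the step of a 4.5-fold higher number from compound 2 to compound 3 (0.65 log units; beyond the scatter), where 4-fluorophenyl replaces 4-methoxybenzyl, although that change also removes the chain carbon that compound 4 retains. Among the measured compounds shown here, a modest rise in the number is therefore expected, probably no larger than that step. The estimated step is a 1.7-fold higher number from compound 1 to compound 4 (0.22 log units; within the scatter). For compound 4 the expected value is 14000 nM, with an estimated range of 5500 nM to 35000 nM.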

Compound 4, half-maximal inhibitory concentration: > 100000 nM
Compound 4 ended at the assay's limit (the forecaster's own chance of this, stated with the estimate: 8%); middle value at least 7.1-fold (0.85 log units) away from the limit.
By their numbers in this assay, from the lowest: compounds 2 and 1 (each within the scatter of the next); then compound 3. At a limit, above all of these: compound 4.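

In this assay, an at least 11-fold higher number from compound 1 to compound 4 (1.07 log units; beyond the scatter) shows that the group on the saturated chain carbon bound to the amide-type nitrogen matters strongly, even when that chain carbon stays in place. Compound 4 reaches a limit of the assay rather than a number, at > 100000 nM. Among the compounds shown here, the earlier 4.5-fold higher number from compound 2 to compound 3 (0.65 log units; beyond the scatter) changed the ring and removed the chain carbon together, whereas here 2,4-difluorophenyl in place of 4-methoxyphenyl is the only change, and the step is large.

The compounds shown leave open whether the step follows from the loss of the methoxy group or the arrival of the two fluorines, which plain phenyl or 4-hydroxyphenyl on the same chain carbon could help to separate. They also leave open how a longer chain on the amide-type nitrogen would read in this assay.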